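Changing the group on the five-membered ring of compound 3

The source may hold more compounds than are shown below. What is called first, only, known or untested is meant among the compounds shown, and "the series" means these compounds.

Measured compounds and their values:
compound 1, `CCOc1ccc(Cc2nnc(CN(c3cccc(Cl)c3Cl)S(=O)(=O)c3ccc(C)cc3)o2)cc1`, 6.31 nM;
compound 2, `Cc1ccc(S(=O)(=O)N(Cc2nnc(Cc3cccc(F)c3)o2)c2cccc(Cl)c2C)cc1`, 316 nM;
compound 3, `CCOc1ccc(Cc2nnc(CN(c3cccc(Cl)c3Cl)S(=O)(=O)c3ccc(C(F)(F)F)cc3)o2)cc1`, 2.51 nM.

All three were tested in an assay on CHO cells for displacement of a labelled ligand from prostaglandin E2 receptor EP1 subtype (Homo sapiens); on this read-out higher numbers stand for weaker inhibition and lower numbers for stronger inhibition. Compound 3 stands lowest of the three numbers. Its nearest neighbour is compound 1, separated by a 2.5-fold lower number from compound 1 to compound 3 (0.40 log units; beyond the scatter), a change that swaps trifluoromethyl in place of methyl on an aromatic carbon. Compound 2 lies far higher; it differs from compound 1 in more than one place, so its two values can only be set side by side, not traced to a single change.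

Compound 4, `COc1ccc(Nc2nnc(CN(c3cccc(Cl)c3Cl)S(=O)(=O)c3ccc(C(F)(F)F)cc3)o2)cc1`, has not yet been measured in this assay. It differs from compound 3 in one place: (4-methoxyphenyl)amino in place of 4-ethoxybenzyl on an aromatic carbon. Within the data shown here, none of the measured steps touches this part of the shared core, so there is no direct guide. Given that the portion being exchanged is large and brings in a hydrogen-bond donor, a weakening relative to compound 3 is expected, with wide uncertainty. The step from compound 3 to compound 4 is therefore estimated as a 6.0-fold higher number from compound 3 to compound 4 (0.78 log units; beyond the scatter). For compound 4 the expected value is 15 nM, in a range from 3 nM to 100 nM.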

Compound 4, half-maximal inhibitory concentration: 7.94 nM
The estimate for compound 4 lay 1.9-fold (0.28 log units) above the measured number, within the range that was stated.
By their numbers in this assay, from the lowest: compound 3; then compounds 1 and 4 (each within the scatter of the next); then compound 2.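

In this assay, among these compounds, exchanging 4-ethoxybenzyl for (4-methoxyphenyl)amino on the five-membered ring gives a 3.2-fold higher number from compound 3 to compound 4 (0.50 log units; beyond the scatter), the first measured step at this place, as the earlier single-place step concerned only methyl and trifluoromethyl elsewhere in the molecule. The step is modest but beyond the scatter, so this position accepts a new group carrying a hydrogen-bond donor, where the leaving group carried none, with only a limited loss of inhibition in this pair. The available data offer no measurement that explains why the number rises.

This single step combines two changes, a nitrogen in place of the carbon linking the aromatic ring and methoxy in place of ethoxy, and their separate contributions cannot be told apart. A 4-methoxybenzyl group at this place would isolate the effect of the linking atom, while a (4-methoxyphenyl)(methyl)amino group would show whether the hydrogen on that nitrogen matters, leaving both questions open here.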